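This account rests on a few compounds, and the source may have more. Where it says the series, first, only, none or still open, it means among the compounds named here.

Measured so far:
Compound 1, `Fc1ccccc1-n1cc(COc2ccc3c(c2)CCC3)nn1`, 21%.
Compound 2, `Brc1ccc(-n2cc(COc3ccc4c(c3)CCC4)nn2)cc1`, "not determined" (no result reported).
Compound 3, `COc1ccc(-n2cc(COc3ccc4c(c3)CCC4)nn2)cc1`, 21.1%.

In an ADME assay on HEK293 cells (Homo sapiens) for inhibition, read by MTT assay, with a stated time of 48 h, tested at 25 uM (a lower number here means less inhibition, a higher number more inhibition at the concentration tested (going by the name of the read-out)), compound 1 and compound 3 give numbers that lie within the scatter of each other; compound 2 has no result. For the measured compounds named here, the only step in this small set, a number 0.1 percentage points higher from compound 1 to compound 3 (within the scatter), exchanges the aryl group on the aromatic nitrogen and does not move the read-out beyond the scatter.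

Compound 4, `Brc1ccccc1-n1cc(COc2ccc3c(c2)CCC3)nn1`, is the next compound to be measured in this assay. It differs from compound 3 in one place: 2-bromophenyl in place of 4-methoxyphenyl on an aromatic nitrogen. Going by the values given here, this is again an exchange of the aryl group on the aromatic nitrogen, the same kind of change as the one step already measured, which was within the scatter. The expectation for compound 4 is therefore a step of a number 0.1 percentage points lower from compound 3 to compound 4 (within the scatter), that is, no change beyond the scatter. Compound 4 is estimated at 21%, with a range from 8% to 36%.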

Compound 4, a percentage reported as inhibition, at one concentration (the size of the read-out at that concentration, not a potency): 16.5%
Compound 4: the middle estimate sits 4.5 percentage points above what was measured; measured number inside the range.
By their numbers in this assay, from the lowest: compounds 4, 1 and 3 (each within the scatter of the next).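

With this assay as the measure, a number 4.6 percentage points lower from compound 3 to compound 4 (within the scatter) is the step when 4-methoxyphenyl, with its hydrogen-bond acceptor, gives way to 2-bromophenyl, without one, so this exchange on the aromatic nitrogen also stays inside the usual variation. The earlier compounds shown here offered no comparison of halogens, and a number 4.5 percentage points lower from compound 1 to compound 4 (within the scatter) is the step for bromo in place of fluoro on an aromatic carbon, again showing no change that can be told from the scatter. Nothing available here accounts for these small steps.

From the compounds shown here alone, whether an amine or a carboxylic acid on the aryl group would move the read-out beyond the scatter remains open. Compound 2 has no result, so it adds no comparison, and the compounds shown say nothing about changes to the shared core.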